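From cyanomethyl to pyrimidin-4-yl on a carbonyl carbon

This account rests on a few compounds, and the source may have more. Where it says the series, first, only, none or still open, it means among the compounds named here.

Compound 1 (`CC(=O)Nc1nc(-c2ccc(Cl)c(C)c2)cs1`): 1000 nM measured
Compound 2 (`N#CCC(=O)NC1=NN(c2ccc(Cl)c(Cl)c2)CC1`): 202000 nM measured

In a physicochemical assay for solubility, measured as kinetic solubility, with a stated time of 1 h, at pH 7.4 (a lower number here means a less soluble compound, a higher number a more soluble compound), compound 2 has the higher number, well beyond the usual scatter above compound 1. Compound 3 (`O=C(NC1=NN(c2ccc(Cl)c(Cl)c2)CC1)c1ccncn1`) has pyrimidin-4-yl in place of cyanomethyl on a carbonyl carbon. For the measured compounds named here, no measured pair shows this kind of change, so any forecast is a judgement. Going by the values given here, compound 2 at 202000 nM is the top number so far and compound 1 at 1000 nM shows how much lower a number can lie, so a drop in this assay beyond the scatter is expected. The estimate is a 5.1-fold lower number from compound 2 to compound 3 (0.70 log units; beyond the scatter) as the expected step. For compound 3 the estimated value is 40000 nM with an expected range between 8000 nM and 150000 nM as its likely span.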

Compound 3, solubility: 13000 nM
Compound 3: middle estimate off by 3.1-fold (0.49 log units), on the high side, and the stated range covers the measured number.
By their numbers in this assay, from the lowest: compound 1; then compound 3; then compound 2.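

Within this assay the group on the carbonyl carbon makes a large difference: with the rest of the molecule unchanged, pyrimidin-4-yl in place of cyanomethyl gives a 16-fold lower number from compound 2 to compound 3 (1.19 log units; beyond the scatter). For the compounds shown here, this is the first single-place comparison, and it shows that this position is sensitive to the change. Nothing measured here explains the step. Still open, as far as these compounds go, is how other groups at this carbonyl carbon would compare, such as a phenyl ring, a pyridine ring or a short chain carrying an amine.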